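Swapping the Benzyl Group for a Cyclopropylmethyl Chain

A few compounds are considered here, and "the series" means these few. Any claim that something is new, unique, unknown or untested is made for them only; others in the source may bear on it.

Measured compounds:
- compound 1, `CCN(Cc1ccccc1)c1cc(C)nc(N(CC)c2ccc(C(C)C)cc2Br)n1`: 17 nM
- compound 2, `CCN(CC)c1cc(C)nc(N(CC)c2c(Br)cc(OC)cc2OC)n1`: 48 nM
- compound 3, `CCN(CC)c1nc(C)nc(N(CC)c2ccc(C(C)=O)cc2Br)n1`: 17 nM

The three measured compounds were tested in an assay on isolated protein for binding affinity to corticotropin-releasing factor receptor 1 (Homo sapiens); on this read-out higher numbers stand for weaker inhibition and lower numbers for stronger inhibition. Compound 1 gives 17 nM, and compound 3 gives 17 nM; at the digits shown these two numbers are level, and both are the lowest of the three. Compound 2 stands furthest from compound 1, with a number that lies beyond the usual scatter of this assay.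

Compound 4, `CCCN(CC1CC1)c1cc(C)nc(N(CC)c2ccc(C(C)C)cc2Br)n1`, is not yet measured. It differs from compound 1 in one place: (cyclopropylmethyl)(propyl)amino in place of benzyl(ethyl)amino on an aromatic carbon. For the measured compounds named here, no pair of measured compounds shows exactly this kind of exchange, so the size of the step can only be estimated. Compound 2, which carries a diethylamino group at the same place, gives a weaker number than compound 1, while compound 3 with the same group is level with compound 1; these differences do not point clearly in one direction. The expectation is a step of roughly a 1.2-fold lower number from compound 1 to compound 4 (0.08 log units; within the scatter), that is, no change beyond the scatter. Compound 4 is therefore expected to give about 14 nM in this assay, with a range from 4 nM to 45 nM.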

Compound 4, inhibition constant: 9 nM
The estimate for compound 4 lay 1.6-fold (0.19 log units) above the measured number; low and high end bracket the measured number.
By their numbers in this assay, from the lowest: compounds 4, 1 and 3 (each within the scatter of the next); then compound 2.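

For the compounds shown here, until now, no two measured compounds differed only at this position, so this is the first direct reading of an exchange there. Benzyl(ethyl)amino carries a six-membered aromatic ring and (cyclopropylmethyl)(propyl)amino a three-membered non-aromatic ring, yet in this assay the step is a 1.9-fold lower number from compound 1 to compound 4 (0.28 log units; within the scatter), which lies within the scatter, so on the core of compound 1 the aromatic ring can be replaced without a change beyond the scatter. Nothing measured here explains why these two groups read alike.

Still open, going by these compounds, is how a group of a different kind, such as a primary amine or a carboxylic acid on a longer chain, would read at this position. Also open, on these data alone, is whether the same exchange would read alike with other groups elsewhere on the core.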